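Swapping the sulfonamide ring of compound 3

The compounds below may be only part of what the source reports. "The series", "measured", "known", "first", "only" and "open" are said of these compounds alone.

Measured so far in a physicochemical assay for lipophilicity; on this read-out higher numbers stand for higher lipophilicity and lower numbers for lower lipophilicity

Compound 1 `O=S(=O)(Nc1ncccn1)c1ccc2c(c1)OCC[C@@H]2c1ccc(C(F)(F)F)cc1-c1ccc(F)nc1` gives 2.8
Compound 2 `Cn1nccc1-c1cc(C(F)(F)F)ccc1[C@H]1CCOc2cc(S(=O)(=O)Nc3ncccn3)ccc21` gives 3.7
Compound 3 `O=S(=O)(Nc1nccs1)c1ccc2c(c1)OCC[C@@H]2c1ccc(C(F)(F)F)cc1-c1ccc(F)cn1` gives 3.5

On these numbers compound 3 cannot be told apart from compound 2, and it lies clearly higher than compound 1. Compound 4 (`O=S(=O)(Nc1ncccn1)c1ccc2c(c1)OCC[C@@H]2c1ccc(C(F)(F)F)cc1-c1ccc(F)cn1`) carries pyrimidin-2-yl in place of 1,3-thiazol-2-yl on a sulfonamide nitrogen. Among the compounds with values here, no measured step makes this exact swap. Within the data shown here, the only step available shows a number 0.90 log units higher from compound 1 to compound 2 (beyond the scatter) and it concerns a different group, so it tells only that one exchange of groups can move this number beyond the scatter. The closest clue is compound 1, which also carries pyrimidin-2-yl and gives 2.8 against compound 3 at 3.5 in this assay although it differs from compound 4 in another group too. A modest fall is therefore expected in this assay with an estimated size of a number 0.40 log units lower from compound 3 to compound 4 (beyond the scatter) and real uncertainty around it. For compound 4 the estimate is 3.1 with an expected range from 2.7 to 3.5 until a measurement is available.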

Compound 4, distribution coefficient: 2.9
Compound 4: middle estimate off by 0.20 log units, on the high side; low and high end bracket the measured number.
By their numbers in this assay, from the lowest: compounds 1 and 4 (each within the scatter of the next); then compounds 3 and 2 (each within the scatter of the next).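

In this assay the sulfonamide nitrogen now has a measured step of its own: with 5-fluoropyridin-2-yl held constant, pyrimidin-2-yl in place of 1,3-thiazol-2-yl gives a number 0.60 log units lower from compound 3 to compound 4 (beyond the scatter) and so moves the number beyond the scatter. With pyrimidin-2-yl held constant on the sulfonamide nitrogen, the aromatic carbon gives a number 0.80 log units lower from compound 2 to compound 4 (beyond the scatter) for 5-fluoropyridin-2-yl in place of 1-methyl-1H-pyrazol-5-yl, but a number 0.10 log units higher from compound 1 to compound 4 (within the scatter) for 5-fluoropyridin-2-yl in place of 6-fluoropyridin-3-yl, so these two fluoropyridine groups cannot be told apart here. No measured evidence accounts for these steps.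

On these data alone, whether 1,3-thiazol-2-yl and pyrimidin-2-yl would differ by a similar amount alongside 1-methyl-1H-pyrazol-5-yl remains open. As far as these compounds go, how a plain phenyl ring or a methyl group on the sulfonamide nitrogen would compare also remains open.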